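Cyclohexyl for phenyl on the anilino nitrogen of compound 2

The source may hold more compounds than are shown below. What is called first, only, known or untested is meant among the compounds shown, and "the series" means these compounds.

Compound 2 `O=c1cc(Nc2ccccc2)cc(-c2ccccc2)o1` sits second highest of the three numbers in a functional assay on KBVIN cells (Homo sapiens) for cytotoxicity, read by MTT assay, with a stated time of 72 h; on this read-out lower numbers stand for an effect already at smaller amounts and higher numbers for an effect only at larger amounts of compound: compound 2 gives 0.15 uM. Compound 3 `COc1ccc(Nc2cc(-c3ccccc3)oc(=O)c2)cc1` gives 0.098 uM, and compound 1 `COc1cccc(Nc2cc(-c3ccccc3)oc(=O)c2)c1` gives 0.55 uM. The steps within the scatter or beyond it are a 1.5-fold lower number from compound 2 to compound 3 (0.18 log units; within the scatter) and a 3.7-fold lower number from compound 1 to compound 2 (0.56 log units; beyond the scatter); both concern methoxy on the aromatic ring, not the nitrogen substituent. Compound 4 `O=c1cc(NC2CCCCC2)cc(-c2ccccc2)o1` carries cyclohexyl in place of phenyl on a nitrogen on an aromatic ring. Going by the values given here, no measured step bears on this change, so the expectation rests on compound 2 alone. In this assay compound 4 is expected to be somewhat weaker, an estimated step of a 5.3-fold higher number from compound 2 to compound 4 (0.73 log units; beyond the scatter). The estimate for compound 4 is 0.8 uM, with a range from 0.15 uM to 5 uM.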

Compound 4, concentration for half-maximal effect: 9.15 uM
Beside the measured number, compound 4's estimate is 11-fold (1.06 log units) below it, outside the stated range (above it).
By their numbers in this assay, from the lowest: compounds 3 and 2 (each within the scatter of the next); then compound 1; then compound 4.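

In this assay cyclohexyl in place of phenyl on the nitrogen gives a 61-fold higher number from compound 2 to compound 4 (1.79 log units; beyond the scatter) and this large step exceeds both methoxy steps seen on the aromatic ring. Both groups count the same heavy atoms, donors and acceptors, so the one counted difference between them is an aromatic against a non-aromatic ring. Nothing at hand accounts for the loss.

Open, as far as these compounds go, is how a pyridyl ring, a benzyl group or a short alkyl chain on the nitrogen would read.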